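Swapping a bromophenyl for a furan on the shared core

The source may hold more compounds than are shown below. What is called first, only, known or untested is meant among the compounds shown, and "the series" means these compounds.

Three compounds built on one core, each ending in a propanoic acid, have been measured in a functional assay on CHO cells for agonist activity at Free fatty acid receptor 1 (Homo sapiens), read by FLIPR and calcium flux, in the presence of a further agent that is not named here; a higher number here means that more compound is needed for the effect, a lower number that less compound is needed. Compound 1 `Cc1cc(-c2noc(COc3ccc(CCC(=O)O)cc3)n2)ccc1F` gives 2120 nM. Compound 2 `Cc1ccc(-c2noc(COc3ccc(CCC(=O)O)cc3)n2)cc1` gives 300 nM. Compound 3 `O=C(O)CCc1ccc(OCc2nc(-c3cccc(Br)c3)no2)cc1` gives 1260 nM, the second highest of the three numbers; it sits closest to compound 1 and furthest from compound 2.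

The steps among them all concern the aromatic group on the core. There was a 7.1-fold lower number from compound 1 to compound 2 (0.85 log units; beyond the scatter), then a 4.2-fold higher number from compound 2 to compound 3 (0.62 log units; beyond the scatter), while a 1.7-fold lower number from compound 1 to compound 3 (0.23 log units; within the scatter).

Compound 4 `O=C(O)CCc1ccc(OCc2nc(-c3ccco3)no2)cc1` is not yet measured. Its change from compound 3 is furan-2-yl in place of 3-bromophenyl on an aromatic carbon. Among the measured compounds shown here, no measured step replaces a six-membered ring with a five-membered heteroaromatic ring, so the bearing of the three known steps is indirect: they show that changing this group moves the number by modest amounts in either direction, and that not every change moves it beyond the scatter. Because a 1.7-fold lower number from compound 1 to compound 3 (0.23 log units; within the scatter) stayed within the scatter, the expectation for compound 4 is a step of a 1.4-fold higher number from compound 3 to compound 4 (0.15 log units; within the scatter), that is, no change beyond the scatter, with wide uncertainty. Compound 4 is thus estimated at 1800 nM, with a range from 500 nM to 6500 nM.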

Compound 4, half-maximal effective concentration: > 100000 nM
Compound 4 was reported as a limit; the forecaster's own chance of this, stated with the estimate: 10%; middle value at least 55-fold (1.74 log units) away from the limit.
By their numbers in this assay, from the lowest: compound 2; then compounds 3 and 1 (each within the scatter of the next). At a limit, above all of these: compound 4.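

Compound 4 is reported in this assay only as a limit, not as a number: the limit of > 100000 nM in this assay, at which 1 of the 4 values shown sits. The earlier steps shown here at this position, all among substituted phenyl groups, were modest or within the scatter, whereas furan-2-yl gives an at least 79-fold higher number from compound 3 to compound 4 (1.89 log units; beyond the scatter), an at least 330-fold higher number from compound 2 to compound 4 (2.52 log units; beyond the scatter) and an at least 47-fold higher number from compound 1 to compound 4 (1.67 log units; beyond the scatter), all large. So the position, on an aromatic carbon of a five-membered aromatic ring with 2 nitrogen and 1 oxygen, between two ring nitrogen atoms, shows a far sharper response to this exchange of a phenyl group for furan-2-yl than to any exchange among the three phenyl groups shown.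

The compounds shown leave open whether this large step goes with the five-membered ring, with its ring oxygen, or with the lack of any substituent on the ring, and the limit leaves open how large the step really is. A thiophene, a methylfuran or an unsubstituted phenyl at this position would help to tell these apart.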